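The compounds below may be only part of what the source reports. "The series", "measured", "known", "first", "only" and "open" are said of these compounds alone.

Values in a functional assay on G-361 cells (Homo sapiens) for cytotoxicity, read by sulforhodamine B assay (on this read-out higher numbers stand for weaker inhibition of growth and lower numbers for stronger inhibition of growth), so far:
compound 1 `CCCCNc1nc(C)nc2c1cnn2-c1ccccc1` gives 2400 nM
compound 2 `CCc1nc(NC(C)C)c2cnn(-c3ccccc3)c2n1` gives 38000 nM
compound 3 `CCCCNc1nc(CC)nc2c1cnn2-c1ccccc1` gives 2020 nM

Compound 3 holds the lowest of the three numbers, but compound 1 sits within the scatter of it; only compound 2 stands apart, a 19-fold lower number from compound 2 to compound 3 (1.27 log units; beyond the scatter). Compound 4 `CCCCNc1nc(C(C)C)nc2c1cnn2-c1ccccc1` differs from compound 3 by methyl in place of hydrogen on a saturated chain carbon bound to an aromatic carbon and a saturated chain carbon. Going by the values given here, the one measured step of the same kind, a 1.2-fold lower number from compound 1 to compound 3 (0.07 log units; within the scatter), stayed within the scatter, so for compound 4 no shift beyond the scatter is expected in this assay, in either direction. Compound 2 gives no guide here: its change is on the nitrogen on an aromatic ring, not on this chain. For compound 4 the estimate is therefore 1800 nM, with a range of 700 nM to 4500 nM. The expected step of a 1.1-fold lower number from compound 3 to compound 4 (0.05 log units; within the scatter) is flat.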

Compound 4, concentration for 50% growth inhibition: > 100000 nM
Compound 4 was reported as a limit (the forecaster's own chance of this, stated with the estimate: 2%); at least 55-fold (1.74 log units) between middle value and limit.
By their numbers in this assay, from the lowest: compounds 3 and 1 (each within the scatter of the next); then compound 2. At a limit, above all of these: compound 4.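

In this assay compound 4 is reported only as a limit, not as a number: the limit of > 100000 nM in this assay, at which 1 of the 4 values shown sits.

The same kind of change is not flat along this series: methyl in place of hydrogen gave a 1.2-fold lower number from compound 1 to compound 3 (0.07 log units; within the scatter), but on the carbon that already bears a saturated chain carbon it gave an at least 49-fold higher number from compound 3 to compound 4 (1.69 log units; beyond the scatter). Isopropyl in place of methyl on the aromatic carbon likewise gave an at least 41-fold higher number from compound 1 to compound 4 (1.61 log units; beyond the scatter).

Open, as far as these compounds go, is whether a straight propyl or a cyclopropyl at this place would stay with compound 3 or fall with compound 4.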